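A few compounds are considered here, and "the series" means these few. Any claim that something is new, unique, unknown or untested is made for them only; others in the source may bear on it.

Measured in an assay on HEK293 cells for inhibition of solute carrier family 22 member 12 (Homo sapiens), read by scintillation counting, with a stated time of 12 min; a lower number here means a stronger inhibitor, a higher number a weaker inhibitor:
- compound 1 `Nc1ccc2nccc(SC3(C(=O)O)CCC3)c2c1` gives 1790 nM
- compound 2 `O=C(O)C1(Sc2ccnc3ccc(O)cc23)CCC1` gives > 10000 nM, which is a limit of the assay and not a number
- compound 3 `Cc1ccc2nccc(SC3(C(=O)O)CCC3)c2c1` gives 343 nM

Among the two numbers actually read, compound 1 has the highest; the nearest is compound 3, and the change goes a 5.2-fold lower number from compound 1 to compound 3 (0.72 log units; beyond the scatter). Compound 2 sits at the limit (the limit of > 10000 nM in this assay, at which 1 of the 3 values shown sits). Compound 4 `O=C(O)C1(Sc2ccnc3ccc(C(F)(F)F)cc23)CCC1` is not yet measured. It differs from compound 1 in one place: trifluoromethyl in place of amino on an aromatic carbon.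

For the measured compounds named here, two measured steps bear on this change, since both alter the same group on the same carbon. Putting a methyl there lowers the number a 5.2-fold lower number from compound 1 to compound 3 (0.72 log units; beyond the scatter), while putting a hydroxy there raises it an at least 5.5-fold higher number from compound 1 to compound 2 (0.74 log units; beyond the scatter). The trifluoromethyl of compound 4 brings no hydrogen-bond donor or acceptor, which places it alongside the methyl rather than the hydroxy in this count. The expected step is therefore a 6.4-fold lower number from compound 1 to compound 4 (0.81 log units; beyond the scatter), a modest lowering. Compound 4 is expected to give about 280 nM, within 60 nM to 1300 nM.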

Compound 4, half-maximal inhibitory concentration: 61.2 nM
The estimate for compound 4 lay 4.6-fold (0.66 log units) above the measured number; the measured number falls inside the stated range.
By their numbers in this assay, from the lowest: compound 4; then compound 3; then compound 1. At a limit, above all of these: compound 2.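

In this assay, this aromatic carbon tolerates more than the methyl of compound 3 had shown, with a 5.6-fold lower number from compound 3 to compound 4 (0.75 log units; beyond the scatter), so methyl does not mark the low end of the numbers at this position. Replacing the amino group gives a 29-fold lower number from compound 1 to compound 4 (1.47 log units; beyond the scatter), and the widest step in the set is an at least 160-fold lower number from compound 2 to compound 4 (2.21 log units; beyond the scatter). Compound 2 gives a limit of the assay and not a number, so that widest step is only a bound: the limit of > 10000 nM in this assay, at which 1 of the 4 values shown sits.

From the compounds shown here alone, whether a chlorine, a nitrile or a methoxy group on this carbon would fall nearer to compound 4 or to compound 1 remains open. Going by these compounds, it is also open whether the same order of groups would hold with an amide in place of the carboxylic acid.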